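Methyl ether to free hydroxy on the chloro-phenyl arm

The source may report more compounds than this note shows. Statements on the series, on what has been measured and on what is new or still open speak of the compounds shown alone.

Compound 1 `O=C(Nc1cccc(-n2cc(-c3ccncc3)c(-c3ccc(Cl)c(O)c3)n2)c1)Nc1cccc(C(F)(F)F)c1`: > 32500 nM
Compound 2 `COc1cc(-c2nn(-c3cccc(NC(=O)Nc4cc(C(F)(F)F)cc(C(F)(F)F)c4)c3)cc2-c2ccncc2)ccc1Cl`: 4480 nM

In a functional assay on MOLT-4 cells (Homo sapiens) for inhibition, read by sulforhodamine B assay, with a stated time of 48 h (a higher number here means a weaker inhibitor of growth, a lower number a stronger inhibitor of growth), compound 1 gives > 32500 nM, which is a limit of the assay and not a number (the limit of > 32500 nM in this assay, at which 1 of the 2 values shown sits). For the measured compounds named here, compound 2 is the only compound with a measured number, giving 4480 nM in this assay. Compound 3 `O=C(Nc1cccc(-n2cc(-c3ccncc3)c(-c3ccc(Cl)c(O)c3)n2)c1)Nc1cc(C(F)(F)F)cc(C(F)(F)F)c1` has not yet been measured; it differs from compound 2 by hydrogen in place of methyl on an oxygen on an aromatic ring. Going by the values given here, no measured pair shows this step. The expected step is a 3.3-fold higher number from compound 2 to compound 3 (0.52 log units; beyond the scatter), toward weaker growth inhibition. Compound 3 is estimated at 15000 nM, in the range 4000 nM to 40000 nM.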

Compound 3, concentration for total growth inhibition: 4360 nM
Compound 3: the middle estimate sits 3.4-fold (0.54 log units) above what was measured; the range from low to high includes it.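

In this assay, methoxy to hydroxy on the chloro-phenyl arm gives a 1.0-fold lower number from compound 2 to compound 3 (0.01 log units; within the scatter), so the methyl on this oxygen can go without a change beyond the scatter. With the hydroxy kept, trifluoromethyl in place of hydrogen on an aromatic carbon gives an at least 7.4-fold lower number from compound 1 to compound 3 (0.87 log units; beyond the scatter), so this second change, and not the first, separates the compounds. The value for compound 1 is a limit of the assay and not a number: the limit of > 32500 nM in this assay, at which 1 of the 3 values shown sits.

Still open, going by these compounds, is whether an ethoxy group or an amine in place of the hydroxy would hold the level of compound 3. Also open, on these data alone, is whether the trifluoromethyl step carries over to the methoxy arm.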